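The compounds below may be only part of what the source reports. "The series", "measured", "known", "first", "only" and "open" are said of these compounds alone.

Compound 1 `COc1ccc(-c2nc3cc[nH]cc-3n2)c(OC)c1`: 0.3 mg/kg
Compound 2 `COc1cc(C)ccc1-c1nc2cc[nH]cc-2n1`: 0.28 mg/kg

Among the measured compounds shown here, in a functional assay on the whole organism with Canis familiaris (Canis lupus familiaris) as the target (on this read-out higher numbers stand for an effect only at larger amounts of compound and lower numbers for an effect already at smaller amounts), compound 1 gives 0.3 mg/kg and compound 2 gives 0.28 mg/kg, so compound 1 stands level with the only other measured compound, within the scatter. Compound 3 `CCSCCOc1cc(OC)ccc1-c1nc2cc[nH]cc-2n1` differs from compound 1 by one change: (ethylsulfanyl)methyl in place of hydrogen on a saturated chain carbon bound to an oxygen on an aromatic ring. This turns a methoxy into a 2-(ethylsulfanyl)ethoxy. For the measured compounds named here, only one measured step bears on it, a 1.1-fold lower number from compound 1 to compound 2 (0.03 log units; within the scatter), and that step is methyl in place of methoxy on an aromatic carbon. Going by the values given here, it is a different and smaller change, and no measured compound carries a longer chain on that oxygen, so it guides the estimate only loosely. No shift beyond the scatter is therefore expected, although a slightly higher number seems the likelier direction, and the uncertainty is wide. The expected step is a 1.3-fold higher number from compound 1 to compound 3 (0.12 log units; within the scatter). Compound 3 is estimated at 0.4 mg/kg, with an expected range from 0.1 mg/kg to 1.5 mg/kg.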

Compound 3, dose for half-maximal effect: 1 mg/kg
Beside the measured number, compound 3's estimate is 2.5-fold (0.40 log units) below it; measured number inside the range.
By their numbers in this assay, from the lowest: compounds 2 and 1 (each within the scatter of the next); then compound 3.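

In this assay, among the compounds shown here, turning the methoxy of compound 1 into a 2-(ethylsulfanyl)ethoxy gives a 3.3-fold higher number from compound 1 to compound 3 (0.52 log units; beyond the scatter), the only step so far that lies beyond the scatter. This shows that the read-out responds to a change on the saturated chain carbon bound to an oxygen on an aromatic ring, whereas the different change in a 1.1-fold lower number from compound 1 to compound 2 (0.03 log units; within the scatter) had left it within the scatter. The response is modest, and the added (ethylsulfanyl)methyl does not abolish the effect, since compound 3 still gives 1 mg/kg. Nothing available explains this shift. As far as these compounds go, whether it follows the chain length or the sulfur remains open, and a plain butoxy chain, or a chain ending in an amine or a carboxylic acid, would help to separate these possibilities.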